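A few compounds are considered here, and "the series" means these few. Any claim that something is new, unique, unknown or untested is made for them only; others in the source may bear on it.

Compound 1, `O=C(CSC(=S)N[C@H]1CCOC1=O)Nc1ccc(F)cc1`: in a functional assay on EC9706 cells (Homo sapiens) for cytotoxicity, read by MTT assay, with a stated time of 72 h (on this read-out higher numbers stand for weaker inhibition and lower numbers for stronger inhibition), compound 1 gives 67100 nM.
Compound 2, `O=C(CSC(=S)N[C@H]1CCOC1=O)Nc1ccc(O)cc1`: in this assay compound 2 gives > 128000 nM, which is a limit of the assay and not a number.
Compound 3, `CC(=O)c1ccc(NC(=O)CSC(=S)N[C@H]2CCOC2=O)cc1`: in this assay compound 3 gives > 128000 nM, likewise a limit and not a number.

Compound 3 thus stands at the upper edge of what this assay can report, together with compound 2, while compound 1 alone carries a number. The change to compound 4, `CCCCc1ccc(NC(=O)CSC(=S)N[C@H]2CCOC2=O)cc1`, is butyl in place of acetyl on an aromatic carbon. Going by the values given here, of the measured steps, the one from compound 1 to compound 3 is the closest guide: an at least 1.9-fold higher number from compound 1 to compound 3 (0.28 log units; that floor lies within the scatter). The step from compound 2 to compound 3 adds nothing readable: a step that the two limits leave unreadable from compound 2 to compound 3. Both are bounded by the limit of > 128000 nM in this assay, at which 2 of the 3 values shown sit. Neither step shows a change at this position that moves the number beyond the scatter. The step from compound 3 to compound 4 is therefore expected to be small, an at least 1.1-fold lower number from compound 3 to compound 4 (0.06 log units; that floor lies within the scatter), with no clear direction. Compound 4 is estimated at 110000 nM, within a range of 40000 nM to 300000 nM, and may well be reported only as a limit.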

Compound 4, half-maximal inhibitory concentration: 44200 nM
Compound 4: middle estimate off by 2.5-fold (0.40 log units), on the high side; measured number inside the range.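

Butyl in place of acetyl is the first change at this position that moves the reading beyond the scatter in this assay: an at least 2.8-fold lower number from compound 3 to compound 4 (0.46 log units; beyond the scatter). Butyl in place of hydroxy gives the same picture, an at least 2.8-fold lower number from compound 2 to compound 4 (0.46 log units; beyond the scatter), so compound 4 joins compound 1 in carrying a number rather than a limit. Against fluoro the step is a 1.5-fold lower number from compound 1 to compound 4 (0.18 log units; within the scatter), so butyl and fluoro cannot be told apart at this position in this assay.

Going by these compounds, whether a longer chain or an amine on this aromatic carbon would lower the number further remains open. On these data alone, the full size of the steps from compound 2 and compound 3 also stays unknown: the limit of > 128000 nM in this assay, at which 2 of the 4 values shown sit.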